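Aryl Amide Replaces the Nitrile on the Shared Core

This account rests on a few compounds, and the source may have more. Where it says the series, first, only, none or still open, it means among the compounds named here.

Three amides built on one core have been tested in an ADME assay on L02 cells (Homo sapiens) for antiproliferative activity, read by MTT assay, with a stated time of 48 h; on this read-out higher numbers stand for weaker inhibition and lower numbers for stronger inhibition. Compound 1 `CCn1c(C(=O)NCCN(C)C)ccc1C(CC)(CC)c1ccc(OCCC(O)(CC)CC)c(C)c1` gives 990 nM. Compound 3 `CCn1c(C(=O)NCCN)ccc1C(CC)(CC)c1ccc(OCCC(O)(CC)CC)c(C)c1` gives 2940 nM. Among the compounds with values here, compound 2 `CCn1c(C(=O)NCC#N)ccc1C(CC)(CC)c1ccc(OCCC(O)(CC)CC)c(C)c1` reaches only the assay limit, > 50000 nM, so its value is a bound rather than a number; it is the single compound sitting at the limit of > 50000 nM in this assay, at which 1 of the 3 values shown sits. Compound 4 `CCn1c(C(=O)Nc2ccc(OC(F)(F)F)cc2)ccc1C(CC)(CC)c1ccc(OCCC(O)(CC)CC)c(C)c1` has not yet been measured; it differs from compound 2 by 4-(trifluoromethoxy)phenyl in place of cyanomethyl on an amide-type nitrogen. The measured steps give a rough frame: an at least 50-fold higher number from compound 1 to compound 2 (1.70 log units; beyond the scatter) and an at least 17-fold lower number from compound 2 to compound 3 (1.23 log units; beyond the scatter) are both large, whereas a 3.0-fold higher number from compound 1 to compound 3 (0.47 log units; beyond the scatter) is modest. None of these steps exchanges an aliphatic group for a 4-(trifluoromethoxy)phenyl group, so they bear on compound 4 only by showing that compound 2 sits at the weak end of the series and that changes on this amide-type nitrogen move the number widely. A step of an at least 3.3-fold lower number from compound 2 to compound 4 (0.52 log units; beyond the scatter) is therefore expected for compound 4, with the number coming off the limit. Compound 4 is estimated at 15000 nM, between 3000 nM and 60000 nM, while a limit again remains quite possible.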

Compound 4, half-maximal inhibitory concentration: > 50000 nM
Compound 4: only a limit was reported; the forecaster's own chance of this, stated with the estimate: 35%; middle value at least 3.3-fold (0.52 log units) away from the limit.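

In this assay, 4-(trifluoromethoxy)phenyl on the amide-type nitrogen gives an at least 17-fold higher number from compound 3 to compound 4 (1.23 log units; beyond the scatter) when it replaces 2-aminoethyl, and an at least 50-fold higher number from compound 1 to compound 4 (1.70 log units; beyond the scatter) when it replaces 2-(dimethylamino)ethyl. Among the four compounds, only compound 1 and compound 3, whose chains carry an amine, give readable numbers, so an aromatic ring at this position behaves no differently from cyanomethyl as far as the read-out can show. Compound 2 and compound 4 now share one limit of the assay, which leaves the step between them unreadable: the limit of > 50000 nM in this assay, at which 2 of the 4 values shown sit.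

The compounds shown leave open whether the amine alone accounts for the readable numbers or whether the ethyl chain carrying it also matters. A longer chain ending in an amine, or a carboxylic acid in place of the amine, would separate these possibilities.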